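This account rests on a few compounds, and the source may have more. Where it says the series, first, only, none or still open, it means among the compounds named here.

Measured so far:
- compound 1, `O=C(CSc1nnnn1-c1cccc2ccccc12)N/N=C/c1ccccc1F`: in an ADME assay on MT4 cells (Homo sapiens) for cytotoxicity, read by MTT assay (a lower number here means that less compound is tolerated, a higher number that more compound is tolerated), compound 1 gives >= 118000 nM
- compound 2, `COc1ccc(/C=N/NC(=O)CSc2nnnn2-c2cccc3ccccc23)c(OC)c1`: in this assay compound 2 gives 28300 nM

For the measured compounds named here, compound 2 carries the only real number in this assay. For compound 1 the value >= 118000 nM is a limit of the assay, not a number. Going by the values given here, the single measured step, an at least 4.1-fold lower number from compound 1 to compound 2 (0.62 log units; beyond the scatter), is therefore only a lower bound on the true gap, since compound 1 sits at the limit of >= 118000 nM in this assay, at which 1 of the 2 values shown sits.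

Compound 3, `COc1cc(/C=N/NC(=O)CSc2nnnn2-c2cccc3ccccc23)ccc1O`, differs from compound 2 in one place: 4-hydroxy-3-methoxyphenyl in place of 2,4-dimethoxyphenyl on a carbon with a double bond to nitrogen. One methoxy stays; the other gives way to a hydroxy, and the count gains one hydrogen-bond donor. The measured step does not bear on this change directly: it exchanges a 2-fluorophenyl for the 2,4-dimethoxyphenyl ring, not one oxygen substituent for another on the same ring. Among the compounds with values here, no step between two methoxy- or hydroxy-bearing rings has been measured here. A move beyond the scatter is not expected in this assay; the estimated step is a 1.2-fold higher number from compound 2 to compound 3 (0.09 log units; within the scatter). Compound 3 is thus expected to give 35000 nM, with a range from 12000 nM to 100000 nM.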

Compound 3, half-maximal cytotoxic concentration: > 287000 nM
Compound 3 was reported as a limit; the forecaster's own chance of this, stated with the estimate: 20%; at least 8.2-fold (0.91 log units) between middle value and limit.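

On a carbon with a double bond to nitrogen, 4-hydroxy-3-methoxyphenyl in place of 2,4-dimethoxyphenyl gives, in this assay, an at least 10-fold higher number from compound 2 to compound 3 (1.00 log units; beyond the scatter), so a change among oxygen substituents on one ring is enough to move this read-out clearly. The value for compound 3 is a limit of the assay, so this size is only a lower bound on the true gap: the limit of > 287000 nM in this assay, at which 1 of the 3 values shown sits. The leaving and entering groups both count 2 hydrogen-bond acceptors while the hydrogen-bond donors go from 0 to 1, a difference that the earlier exchange of 2-fluorophenyl for 2,4-dimethoxyphenyl did not isolate.

On these data alone, compound 1 and compound 3 both stand at limits, and the step between them cannot be read, so their order remains open. The exchange also removes one methoxy and rearranges the other at the same time, which leaves open whether the hydroxy itself goes with the shift, and whether an amine or a carboxylic acid in place of that hydroxy would behave alike.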